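The source may hold more compounds than are shown below. What is called first, only, known or untested is meant among the compounds shown, and "the series" means these compounds.

Of the compounds shown here, two have numbers so far. In an assay on HeLa cells for agonist activity at Bile acid receptor (Homo sapiens), read by a luciferase reporter, with a stated time of 24 h (a higher number here means that more compound is needed for the effect, a lower number that less compound is needed), compound 1 `CS(=O)(=O)Nc1ccc(CNC(=O)c2ccc(C34CC(C3)C4)cc2)c(Cl)c1` gives 560 nM, while compound 2 `CC(C)(O)c1ccc(C(=O)NCc2ccc(NS(C)(=O)=O)cc2Cl)cc1` gives 32 nM. Within the data shown here, compound 2 therefore holds the lower of the two numbers, and the single known step, an 18-fold lower number from compound 1 to compound 2 (1.24 log units; beyond the scatter), is a large one that lies beyond the scatter.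

Compound 3 `CS(=O)(=O)Nc1ccc(CNC(=O)c2ccc(CC(F)(F)F)cc2)c(Cl)c1` is the next member and has not been measured. It differs from compound 2 in one place: 2,2,2-trifluoroethyl in place of 1-hydroxy-1-methylethyl on an aromatic carbon. Among the measured compounds shown here, the only step that bears on this change is an 18-fold lower number from compound 1 to compound 2 (1.24 log units; beyond the scatter), in which the same 1-hydroxy-1-methylethyl group that now leaves had entered in place of a group of carbon only, with no hydrogen-bond donor and no acceptor; what now enters, the 2,2,2-trifluoroethyl group, also counts 0 hydrogen-bond donors and 0 hydrogen-bond acceptors. On that basis a step of some size upward is expected for compound 3, roughly a 7.8-fold higher number from compound 2 to compound 3 (0.89 log units; beyond the scatter), though smaller than the known step because compound 1 gave 560 nM with a ring-bearing group. Compound 3 is thus estimated at 250 nM, within a range of 80 nM to 800 nM.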

Compound 3, half-maximal effective concentration: 4000 nM
The estimate for compound 3 lay 16-fold (1.20 log units) below the measured number; the measured number lies above the stated range.
By their numbers in this assay, from the lowest: compound 2; then compound 1; then compound 3.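

The result shows that in this assay, this position on the aromatic ring tolerates far less than the first step suggested: replacing 1-hydroxy-1-methylethyl with 2,2,2-trifluoroethyl gives a 130-fold higher number from compound 2 to compound 3 (2.10 log units; beyond the scatter) and so costs more than the earlier step had gained. The two groups without a hydrogen-bond donor or acceptor are also not interchangeable, since they count the same number of heavy atoms and yet there is a 7.1-fold higher number from compound 1 to compound 3 (0.85 log units; beyond the scatter) with 2,2,2-trifluoroethyl in place of the ring-bearing carbon group. Among these three compounds, only compound 2, the one whose group carries a hydrogen-bond donor and acceptor, reaches the lowest number, but nothing shown gives a measured reason for the differences between these groups.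

The compounds shown leave open whether the hydroxyl of the 1-hydroxy-1-methylethyl group or its branched carbon frame accounts for the low number of compound 2. A tert-butyl group, a methoxy ether of the same frame, or an amine or carboxylic acid in place of the hydroxyl would separate these two readings.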